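Side-chain homologation on two aryl cores: working notes

The compounds below may be only part of what the source reports. "The series", "measured", "known", "first", "only" and "open" are said of these compounds alone.

Measured so far:
- compound 1, `Nc1nc(NCCCc2ccccc2)nc(-c2c(F)cccc2CO)n1`, gives 4.47 in a functional assay on cells for positive allosteric modulation of G-protein coupled receptor 68 (Homo sapiens), read by a luciferase reporter and cAMP accumulation, with a stated time of 30 min, at pH 6.8 and pH 8.3, in the presence of a further agent that is not named here; a higher number here means a more potent compound, by a factor of ten per unit of this negative logarithm, a lower number a less potent compound
- compound 2, `Nc1nc(NCCCCc2ccccc2)nc(-c2c(F)cccc2CO)n1`, gives 4.04
- compound 3, `Nc1nc(NCCCc2ccccc2)nc(-c2cc(Cl)ccc2CO)n1`, gives 5.35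

Compound 1 and compound 2 share a core and differ in one place: benzyl in place of phenyl on a saturated chain carbon, three bonds along the chain from a nitrogen on an aromatic ring
That change moved the read-out a number 0.43 log units lower from compound 1 to compound 2 (beyond the scatter), a modest loss that lies beyond the usual scatter of this measurement.

Compound 3 carries a different core. How it differs from compound 1 is not broken down here. In this assay compound 3 stands highest of the three numbers, beyond the scatter from both compound 1 and compound 2, so it is the most potent compound measured.

Compound 4, `Nc1nc(NCCCCc2ccccc2)nc(-c2cc(Cl)ccc2CO)n1`, has not yet been measured. It relates to compound 3 exactly as compound 2 relates to compound 1: benzyl in place of phenyl on a saturated chain carbon, three bonds along the chain from a nitrogen on an aromatic ring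
The place of the change is described in the same words in both pairs, so this is the same change on a different core.

Going by the values given here, with only one prior instance of the change, the expectation for compound 4 rests on that single step, a loss from compound 1 to compound 2 of a number 0.43 log units lower from compound 1 to compound 2 (beyond the scatter). Compound 4 is therefore expected to fall below compound 3 by about the same amount, an estimated step of a number 0.43 log units lower from compound 3 to compound 4 (beyond the scatter). The estimate for compound 4 is 4.92, with a range from 4.5 to 5.35, the width reflecting that the change has so far been seen on one core only.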

Compound 4, negative logarithm of the antagonist equilibrium constant: 4.98
The estimate for compound 4 lay 0.06 log units below the measured number, within the range that was stated.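

In this assay, benzyl in place of phenyl on a saturated chain carbon gives a number 0.37 log units lower from compound 3 to compound 4 (beyond the scatter), and the two instances of this change agree across the two cores: the same change on two cores in this assay, a number 0.43 log units lower (beyond the scatter) from compound 1 to compound 2 and a number 0.37 log units lower (beyond the scatter) from compound 3 to compound 4, 0.06 log units apart, within the scatter of two such steps

The difference between the cores also persists on the longer chain, with a number 0.94 log units higher from compound 2 to compound 4 (beyond the scatter), so within these four compounds the core change and the chain change read as independent of each other. This shows that the change carried over between two cores, at a single chain length and in a single assay; it does not show that the same step would hold on any other core, and it gives no explanation for the loss.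

The compounds shown leave open whether the downward step continues with a longer chain than the one in compound 4, and what happens when an amine or a carboxylic acid takes the place of the terminal phenyl. Also open, going by these compounds, is whether the step keeps its size on a core carrying a nitrile or a methoxy group in place of the chloro substituent of compound 3.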